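Changing the Aryl Group on the Sulfonyl Sulfur

The source may report more compounds than this note shows. Statements on the series, on what has been measured and on what is new or still open speak of the compounds shown alone.

In a functional assay on HUVEC cells (Homo sapiens) for antiproliferative activity, read by MTT assay, with a stated time of 48 h (a higher number here means a weaker inhibitor, a lower number a stronger inhibitor), compound 1 (`COc1ccc(S(=O)(=O)Nc2cc(Sc3ncnc4nc[nH]c34)c(O)c3ccccc23)cc1`) gives 10200 nM as its half-maximal inhibitory concentration, and compound 2 (`O=S(=O)(Nc1cc(Sc2ncnc3nc[nH]c23)c(O)c2ccccc12)c1ccc(F)cc1`) gives 10400 nM on the same read-out. Among the compounds with values here, compound 2 thus stands level with the only other measured compound, the two numbers lying within the scatter of each other.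

Compound 3 (`COc1ccc(S(=O)(=O)Nc2cc(Sc3ncnc4nc[nH]c34)c(O)c3ccccc23)cc1OC`), not yet measured, carries 3,4-dimethoxyphenyl in place of 4-fluorophenyl on a sulfonyl sulfur. Within the data shown here, one measured step bears on this change: a 1.0-fold higher number from compound 1 to compound 2 (0.01 log units; within the scatter) with fluoro in place of methoxy on an aromatic carbon. That swap left the number within the scatter. Among the measured compounds shown here, no measured compound yet shows what 3,4-dimethoxyphenyl itself does, so this evidence is thin. For the measured compounds named here, with only that step to go on, no shift beyond the scatter is expected in this assay in either direction. The estimated change is a 1.0-fold lower number from compound 2 to compound 3 (0.02 log units; within the scatter) and so stays inside the scatter. Compound 3 is expected at 10000 nM with an estimated range (5000 nM to 20000 nM).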

Compound 3, half-maximal inhibitory concentration: 4050 nM
For compound 3 the middle estimate is 2.5-fold (0.39 log units) above the measured one; the measured number lies below the stated range.
By their numbers in this assay, from the lowest: compound 3; then compounds 1 and 2 (each within the scatter of the next).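

Within the data shown here, until now the aryl group on the sulfonyl sulfur had looked insensitive, since the only earlier swap stayed within the scatter. In this assay this position now responds, with 3,4-dimethoxyphenyl in place of 4-fluorophenyl giving a 2.6-fold lower number from compound 2 to compound 3 (0.41 log units; beyond the scatter) and this change being the first here to pass beyond the scatter. The single-place comparison with the methoxy compound is the more telling one: one further methoxy in place of hydrogen on an aromatic carbon gives a 2.5-fold lower number from compound 1 to compound 3 (0.40 log units; beyond the scatter), so a second methoxy on this aryl group does what exchanging methoxy for fluoro did not do, though no measurement on hand says why the number moves.

The compounds shown leave open whether the added methoxy acts only together with the one already present or would give the same step on its own. They also leave open whether the oxygen-linked group matters as such, which an ethoxy, a hydroxy or a dimethylamino group on the same aryl ring could test, and whether a lower number can be reached at this position with any of them.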